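The compounds below may be only part of what the source reports. "The series", "measured", "known", "first", "only" and "open" are said of these compounds alone.

Measured compounds:
- compound 1 `Cc1ccc(C(=O)Nc2ccc(-c3nc4c([nH]3)c(=O)n(C)c(=O)n4C)cc2)cc1`: 2770 nM
- compound 2 `COc1ccc(C(=O)Nc2ccc(-c3nc4c([nH]3)c(=O)n(C)c(=O)n4C)cc2)cc1`: 3970 nM
- compound 3 `Cn1c(=O)c2c(nc(-c3ccc(NC(=O)c4ccccc4)cc3)n2C)n(C)c1=O`: 260 nM

In an assay for inhibition of Amine oxidase [flavin-containing] B (Mus musculus), read by fluorescence, with a stated time of 30 min, in the presence of a further agent that is not named here (on this read-out lower numbers stand for stronger inhibition and higher numbers for weaker inhibition), compound 3 gives the lowest of the three numbers, meaning the strongest inhibition seen here; compound 1 and compound 2 both sit well above it, beyond the scatter. Compound 4 `Cc1ccc(C(=O)Nc2ccc(-c3nc4c(c(=O)n(C)c(=O)n4C)n3C)cc2)cc1` is not yet measured. It differs from compound 3 in one place: methyl in place of hydrogen on an aromatic carbon, on an aromatic carbon of a six-membered aromatic ring of carbon only, read one bond further out as benzamido to ((4-methylphenyl)carbonyl)amino.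

For the measured compounds named here, no measured pair shows exactly this hydrogen-to-methyl exchange. Going by the values given here, the only measured single step, a 1.4-fold higher number from compound 1 to compound 2 (0.16 log units; within the scatter), swaps one small group for another at the same position and stays within the scatter, which suggests that this part of the molecule tolerates small changes without a large shift. The expected step of a 1.3-fold higher number from compound 3 to compound 4 (0.13 log units; within the scatter) is therefore none beyond the scatter. Compound 4 is estimated at 350 nM, with a range from 150 nM to 900 nM.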

Compound 4, inhibition constant: 1630 nM
Beside the measured number, compound 4's estimate is 4.7-fold (0.67 log units) below it; the whole stated range lies below it.
By their numbers in this assay, from the lowest: compound 3; then compounds 4, 1 and 2 (each within the scatter of the next, the first and the last beyond it).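

In this assay, the ring carbon para to a large group proves sensitive, since a single added methyl gives a 6.3-fold higher number from compound 3 to compound 4 (0.80 log units; beyond the scatter) and turns the phenyl of compound 3 into the 4-methylphenyl of compound 4. The methyl-to-methoxy step had suggested that this site tolerates small changes, but that step compared two substituted rings and so could not show what the unsubstituted ring offers. With the 4-methylphenyl group in place, methyl on the aromatic nitrogen gives only a 1.7-fold lower number from compound 1 to compound 4 (0.23 log units; within the scatter) and no evidence here explains either result.

The compounds shown leave open whether fluorine, an amine or a carboxylic acid on this ring carbon would stay close to compound 3 or fall nearer compound 4. They also leave open whether methoxy on this ring carbon would behave like methyl when the aromatic nitrogen carries a methyl.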